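This account rests on a few compounds, and the source may have more. Where it says the series, first, only, none or still open, it means among the compounds named here.

Measured so far in a functional assay on FM3A cells (Mus musculus) for antiproliferative activity, with a stated time of 48 h; on this read-out higher numbers stand for weaker inhibition and lower numbers for stronger inhibition:
compound 1 `C=C(Br)C(=O)Nc1ccc(C(=O)/C=C/c2cc(OC)c(OC)c(OC)c2)cc1`: 1800 nM
compound 2 `COc1cccc(/C=C/C(=O)c2ccc(N)cc2)c1`: 45000 nM
compound 3 `COc1cc(/C=C/C(=O)c2ccc(N)cc2)cc(OC)c1`: 12000 nM

Compound 3 holds the second highest of the three numbers, with compound 2 higher and compound 1 lower. Compound 4 `COc1cc(/C=C/C(=O)c2ccc(N)cc2)cc(OC)c1OC` is not yet measured. The change is methoxy in place of hydrogen on an aromatic carbon, ortho to two methoxy groups and para to a large group. One measured step is of the same kind: a 3.8-fold lower number from compound 2 to compound 3 (0.57 log units; beyond the scatter). For the measured compounds named here, compound 1 also differs elsewhere, so it gives no clean step. A modest move toward a lower number in this assay is therefore expected, though one within the scatter remains possible. The estimated step is a 2.4-fold lower number from compound 3 to compound 4 (0.38 log units; beyond the scatter). For compound 4 the expected value is 5000 nM, with an estimated range of 1500 nM to 15000 nM.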

Compound 4, half-maximal inhibitory concentration: 8800 nM
For compound 4 the middle estimate is 1.8-fold (0.25 log units) below the measured one; low and high end bracket the measured number.
By their numbers in this assay, from the lowest: compound 1; then compounds 4 and 3 (each within the scatter of the next); then compound 2.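

In this assay, methoxy in place of hydrogen, ortho to two methoxy groups and para to a large group, gives no gain that can be read (a 1.4-fold lower number from compound 3 to compound 4 (0.13 log units; within the scatter)), unlike the earlier methoxy step (a 3.8-fold lower number from compound 2 to compound 3 (0.57 log units; beyond the scatter)). Hydrogen in place of (1-bromoethenyl)carbonyl on the nitrogen gives the first clean step at that nitrogen (a 4.9-fold higher number from compound 1 to compound 4 (0.69 log units; beyond the scatter)). No measured evidence bears on the reason for either result.

On these data alone, whether ethoxy or hydroxy at this position would read differently from methoxy remains open. Also open, as far as these compounds go, is whether a plain acetyl on the nitrogen would match compound 1, which would separate the carbonyl from the bromoethenyl part.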